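A Bulkier Sulfur Side Chain on a Neprilysin Inhibitor Amide

This account rests on a few compounds, and the source may have more. Where it says the series, first, only, none or still open, it means among the compounds named here.

Of the compounds shown here, three sharing one core have been measured in an assay on isolated protein for inhibition of Neprilysin (Oryctolagus cuniculus); a higher number here means a weaker inhibitor, a lower number a stronger inhibitor. Compound 1 `CCSC[C@@H](NC(=O)[C@@H](CS)Cc1ccccc1)C(=O)O`, the free acid, gives 2.4 nM. Compound 2 `CSCC[C@@H](NC(=O)[C@@H](CS)Cc1ccccc1)C(N)=O`, which carries a primary amide in place of the acid, gives 76 nM, and its epimer compound 3 `CSCC[C@@H](NC(=O)[C@H](CS)Cc1ccccc1)C(N)=O` gives 94 nM. Among these three numbers compound 2 stands second highest, with compound 3 nearest and compound 1 far lower.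

Among the measured compounds shown here, the only single-point step measured so far is a 1.2-fold higher number from compound 2 to compound 3 (0.09 log units; within the scatter), which rests on (the fact that compounds 2 and 3 differ only in the configuration as drawn). It concerns configuration alone and says nothing about what happens when the side chain is enlarged.

Compound 4 `Cc1ccc(CSC[C@@H](NC(=O)[C@@H](CS)Cc2ccccc2)C(N)=O)cc1` is not yet measured. It differs from compound 2 by (4-methylbenzyl)sulfanyl in place of (methylsulfanyl)methyl on a saturated chain carbon, two bonds along the chain from an amide-type nitrogen and a carbonyl carbon. For the measured compounds named here, no measured pair covers a change of this kind, so the expectation leans on the position of compound 2 alone. The change is expected to move the number only modestly, most likely toward a lower value, and a step of a 1.9-fold lower number from compound 2 to compound 4 (0.28 log units; within the scatter) is estimated from compound 2 to compound 4. In this assay compound 4 is therefore estimated at 40 nM, within a range from 8 nM to 200 nM.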

Compound 4, half-maximal inhibitory concentration: > 300 nM
Compound 4: no number, only a limit (the forecaster's own chance of this, stated with the estimate: 2%); middle value at least 7.5-fold (0.87 log units) from the limit.
By their numbers in this assay, from the lowest: compound 1; then compounds 2 and 3 (each within the scatter of the next). At a limit, above all of these: compound 4.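

At this saturated chain carbon, two bonds along the chain from an amide-type nitrogen and a carbonyl carbon, enlarging the side chain does not leave inhibition unchanged: putting (4-methylbenzyl)sulfanyl in place of (methylsulfanyl)methyl gives an at least 3.9-fold higher number from compound 2 to compound 4 (0.59 log units; beyond the scatter) in this assay. Compound 4 stands at > 300 nM, which is a limit of the assay and not a number, so this step gives a direction and a minimum size only. Within this pair, the group with one six-membered aromatic ring of carbon only, and 9 heavy atoms against 3, gives the weaker inhibitor, and that reading rests on a limit: the limit of > 300 nM in this assay, at which 1 of the 4 values shown sits.

The compounds shown cannot separate the part played by the size of the entering group from that of its aromatic ring or of the methyl on that ring, as this is the only change covered at this position. As far as these compounds go, a benzylsulfanyl group without that methyl, or a longer straight alkyl chain on the sulfur, would help to tell these apart, and whether the same change behaves alike on the free acid of compound 1 also stays open.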